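Swapping the aromatic ring on the thioether chain

The source may report more compounds than this note shows. Statements on the series, on what has been measured and on what is new or still open speak of the compounds shown alone.

Measured so far in a functional assay on PC-3 cells (Homo sapiens) for inhibition, read by MTT assay, with a stated time of 48 h; a lower number here means a stronger inhibitor, a higher number a weaker inhibitor:
- compound 1 `C=C1CC[C@@H]2[C@](C)(CO)[C@H](O)CC[C@@]2(C)[C@@H]1C/C=C1/C(=O)OC[C@H]1OC(=O)CCCSc1ccc([N+](=O)[O-])cc1` gives 17000 nM
- compound 2 `C=C1CC[C@@H]2[C@](C)(CO)[C@H](O)CC[C@@]2(C)[C@@H]1C/C=C1/C(=O)OC[C@H]1OC(=O)CCCSc1ccc(C)cc1` gives 16000 nM

Compound 2 has the lowest of the two numbers, but its nearest neighbour, compound 1, sits only a 1.1-fold lower number from compound 1 to compound 2 (0.03 log units; within the scatter) away, so the two cannot be told apart. Compound 3 `C=C1CC[C@@H]2[C@](C)(CO)[C@H](O)CC[C@@]2(C)[C@@H]1C/C=C1/C(=O)OC[C@H]1OC(=O)CCCSc1ccccn1` is not yet measured. It differs from compound 2 in one place: pyridin-2-yl in place of 4-methylphenyl on a sulfur.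

Within the data shown here, only one measured step bears on this change, and it is a distant relative: the step from compound 1 to compound 2 replaced one substituent on the same aromatic ring with another and gave a 1.1-fold lower number from compound 1 to compound 2 (0.03 log units; within the scatter). Replacing the whole ring with pyridin-2-yl is a larger change, yet there is no measured evidence that anything on this ring moves the number beyond the scatter. The expectation for compound 3 is therefore a step of about no change at the digits printed from compound 2 to compound 3 (within the scatter), that is, no real change. Compound 3 is estimated at 16000 nM, with a range from 6000 nM to 45000 nM.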

Compound 3, half-maximal inhibitory concentration: 14000 nM
For compound 3 the middle estimate is 1.1-fold (0.06 log units) above the measured one; low and high end bracket the measured number.
By their numbers in this assay, from the lowest: compounds 3, 2 and 1 (each within the scatter of the next).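

Until now only a substituent on the aromatic ring had been exchanged; here the whole ring on the sulfur is replaced, and in this assay this gives a 1.1-fold lower number from compound 2 to compound 3 (0.06 log units; within the scatter). Set against the 4-nitrophenyl ring, the same replacement gives a 1.2-fold lower number from compound 1 to compound 3 (0.08 log units; within the scatter), so pyridin-2-yl, with a nitrogen in its ring, cannot be told apart from either carbon-only ring in this assay. No available measurement offers an explanation for this flat result.

Still open, going by these compounds, is whether anything at this position can move the number beyond the scatter, for example an amine or a carboxylic acid on the ring. Also open, on these data alone, is whether a longer chain leading to the sulfur, or an oxygen in place of that sulfur, would matter more than the ring itself.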